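Amide substituent variation and expected maximal response

The source may report more compounds than this note shows. Statements on the series, on what has been measured and on what is new or still open speak of the compounds shown alone.

Compound 2 `CCNC(=O)c1sc2nc(SC)nc(-c3cccc(OC)c3)c2c1N` stands lowest of the two measured compounds: in a functional assay on HEK293 cells for agonist activity at lutropin-choriogonadotropic hormone receptor (Homo sapiens), read by cAMP accumulation (on this read-out lower numbers stand for smaller maximal responses and higher numbers for larger maximal responses), compound 2 gives 26.9%, while compound 1 `COc1cccc(-c2nc(SC)nc3sc(C(=O)N(C)C(C)(C)C)c(N)c23)c1` gives 47.8%. Going by the values given here, the single measured step, a number 20.9 percentage points lower from compound 1 to compound 2 (beyond the scatter), concerns the same amide-type nitrogen that is altered here. Compound 3 `COc1cccc(-c2nc(SC)nc3sc(C(=O)NNC(=O)OC(C)(C)C)c(N)c23)c1` differs from compound 2 as follows: (tert-butoxycarbonyl)amino in place of ethyl on an amide-type nitrogen. The step of a number 20.9 percentage points lower from compound 1 to compound 2 (beyond the scatter) shows that the group on this nitrogen can move the maximal response beyond the scatter, and that the larger group, which also contains a tert-butyl, went with the higher number. Among the compounds with values here, no measured pair contains the entering (tert-butoxycarbonyl)amino group, so the direction remains uncertain. Compound 3 is therefore expected to recover part of that drop, by an estimated a number 9.1 percentage points higher from compound 2 to compound 3 (within the scatter). Compound 3 is expected to give 36%, within 15% to 60%.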

Compound 3, largest response reached (reported as efficacy), in percent of the reference or control that the assay uses: 2.4%
Compound 3: the middle estimate sits 33.6 percentage points above what was measured; measured number outside the range, below it.
By their numbers in this assay, from the lowest: compound 3; then compound 2; then compound 1.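

In this assay, (tert-butoxycarbonyl)amino on the amide-type nitrogen gives a number 24.5 percentage points lower from compound 2 to compound 3 (beyond the scatter) and is not tolerated as the earlier step might have suggested, so this position can lose nearly all of the maximal response and not only part of it. The change cut one bond further out, ((tert-butoxycarbonyl)amino)amino in place of methyl(tert-butyl)amino on the carbonyl carbon, gives a number 45.4 percentage points lower from compound 1 to compound 3 (beyond the scatter) and shows that neither a larger group nor a tert-butyl goes with the higher number in this short series: compound 3 goes against both readings. No measurement shown speaks to the reason for this loss.

The compounds shown do not separate the added nitrogen from the tert-butoxycarbonyl part of the entering group. A plain amino or an acetylamino group on the same nitrogen would address that, and a tert-butyl on that nitrogen would show how much of the response of compound 1 needs the methyl.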